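Replacing the Triazolyl Ring with a Carbamoylmethyl Chain

The compounds below may be only part of what the source reports. "The series", "measured", "known", "first", "only" and "open" are said of these compounds alone.

Compound 2 `CC(C)C(c1nnc[nH]1)c1ccc(-c2ccc3cccc(F)c3c2)[nH]c1=O` has the lowest number of the three measured compounds in a functional assay on CHO cells for antagonist activity at prostaglandin E2 receptor EP3 subtype (Homo sapiens), read by cAMP accumulation; on this read-out higher numbers stand for weaker inhibition and lower numbers for stronger inhibition: compound 2 gives 21 nM, while compound 1 `CCn1ncc2c(F)cc(-c3ccc(C(CC)(CC)c4nnc(C)[nH]4)c(=O)[nH]3)cc21` gives 90 nM and compound 3 `CCn1ncc2c(F)cc(-c3ccc(C(CC)(CC)c4ncn(C)n4)c(=O)[nH]3)cc21` gives 96 nM, both lying beyond the scatter above compound 2. Compound 4 `CC(C)C(CC(N)=O)c1ccc(-c2ccc3cccc(F)c3c2)[nH]c1=O` has not yet been measured. It differs from compound 2 in one place: carbamoylmethyl in place of 4H-1,2,4-triazol-3-yl on a saturated chain carbon bound to an aromatic carbon and a saturated chain carbon. Going by the values given here, the only measured step that touches this part of the molecule, a 1.1-fold higher number from compound 1 to compound 3 (0.03 log units; within the scatter), exchanged one five-membered aromatic ring for another and stayed within the scatter. Among the compounds with values here, no measured step removes the ring altogether and puts an open chain in its place, so the outcome of this change is untested here. Since the change is larger than the one behind a 1.1-fold higher number from compound 1 to compound 3 (0.03 log units; within the scatter), a weakening step is expected rather than none. Compound 4 is therefore estimated to give 80 nM in this assay, within a range from 20 nM to 400 nM. That estimate corresponds to an expected step of a 3.8-fold higher number from compound 2 to compound 4 (0.58 log units; beyond the scatter).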

Compound 4, half-maximal inhibitory concentration: 53 nM
The estimate for compound 4 lay 1.5-fold (0.18 log units) above the measured number; low and high end bracket the measured number.
By their numbers in this assay, from the lowest: compound 2; then compounds 4, 1 and 3 (each within the scatter of the next).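

The open carbamoylmethyl chain can take the place of the 4H-1,2,4-triazol-3-yl ring on this saturated chain carbon at a modest cost: a 2.5-fold higher number from compound 2 to compound 4 (0.40 log units; beyond the scatter) in this assay. The earlier step at this place only exchanged one five-membered aromatic ring for another, whereas compound 4 has no ring there and still gives 53 nM, so an aromatic ring at this place is not essential for activity in this series, although the step shows that the ring gives the lower number. No measured property of these groups is available to account for the size of this step.

Open, as far as these compounds go, is how a carboxylic acid or an amine on this carbon would compare with the carbamoylmethyl chain, and whether a longer chain ending in the same amide would do better or worse. Also open, from the compounds shown here alone, is whether the same exchange would give a similar step on the core of compound 1.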